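This account rests on a few compounds, and the source may have more. Where it says the series, first, only, none or still open, it means among the compounds named here.

Measured compounds:
- compound 1, `CCCCc1cc(C(=O)O)nn1Cc1cc(Br)ccc1OCc1ccccc1`: 977 nM
- compound 2, `O=C(O)c1cncn1Cc1cc(Br)ccc1OCc1ccccc1`: < 2000 nM

In a functional assay on CHO-K1 cells for antagonist activity at prostaglandin E2 receptor EP1 subtype (Homo sapiens), read by FLIPR (a lower number here means a stronger inhibitor, a higher number a weaker inhibitor), compound 1 gives 977 nM. For compound 2 only a limit of the assay is known: compound 2 gives < 2000 nM, which is the limit of < 2000 nM in this assay, at which 1 of the 2 values shown sits, so its true standing on the scale is not fixed by the numbers at hand. Compound 3, `O=C(O)c1cn(Cc2cc(Br)ccc2OCc2ccccc2)nn1`, has not yet been measured. It differs from compound 2 in one place: 4-carboxy-1H-1,2,3-triazol-1-yl in place of 5-carboxy-1H-imidazol-1-yl on a saturated chain carbon bound to an aromatic carbon. For the measured compounds named here, no pair of measured compounds shows the effect of this kind of change, so the size of the step in this assay cannot be read from the data; with the shared core otherwise untouched, no shift beyond the usual scatter is expected in either direction. For compound 3 a value of about 1500 nM is estimated, with a likely range from 300 nM to 6000 nM. This estimate corresponds to an expected step that the limit leaves unreadable from compound 2 to compound 3.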

Compound 3, inhibition constant: < 2000 nM
Compound 3 ended at the assay's limit; the forecaster's own chance of this, stated with the estimate: 40%; the middle value does not contradict the limit.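

Compound 2 and compound 3 both sit at a limit rather than at a number, so no step between them can be read: the limit of < 2000 nM in this assay, at which 2 of the 3 values shown sit.

The compounds shown leave open whether 4-carboxy-1H-1,2,3-triazol-1-yl in place of 5-carboxy-1H-imidazol-1-yl changes inhibition at all.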